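Swapping the amide substituents on the most potent compound

The source may report more compounds than this note shows. Statements on the series, on what has been measured and on what is new or still open speak of the compounds shown alone.

Measurements in an assay on HL-60 cells for agonist activity at vitamin D3 receptor (Homo sapiens), read by microscopy, with a stated time of 96 h (on this read-out lower numbers stand for an effect already at smaller amounts and higher numbers for an effect only at larger amounts of compound), exist for three compounds that share one core. Compound 1 `CCOC(=O)CN(C)C(=O)c1ccc(C(CC)(CC)c2ccc(OCC(=O)C(C)(C)C)c(C)c2)n1CC` reaches only the assay limit, > 50000 nM. Compound 2 `CCn1c(C(=O)N(C)CCC#N)ccc1C(CC)(CC)c1ccc(OCC(=O)C(C)(C)C)c(C)c1` gives 9800 nM, and compound 3 `CCOC(=O)CN(C)C(=O)c1ccc(C(CC)(CC)c2ccc(OCC(O)C(C)(C)C)c(C)c2)n1CC` gives 210 nM, the lowest of the two numbers recorded; its nearest neighbour is compound 2, whose number is higher by a gap beyond the usual scatter. The step of an at least 230-fold lower number from compound 1 to compound 3 (2.37 log units; beyond the scatter) is large, and the step of an at least 5.1-fold lower number from compound 1 to compound 2 (0.70 log units; beyond the scatter) is at least modest, though it rests on the limit (the limit of > 50000 nM in this assay, at which 1 of the 3 values shown sits).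

Compound 4 `CCn1c(C(=O)N(CCC#N)CCC#N)ccc1C(CC)(CC)c1ccc(OCC(O)C(C)(C)C)c(C)c1` keeps the 1-hydroxy-2,2-dimethylpropyl group of compound 3 and changes the amide side instead: a group of 9 heavy atoms (6 carbon, 3 nitrogen; no ring) in place of a group of 8 heavy atoms (5 carbon, 1 nitrogen, 2 oxygen; no ring), on a carbonyl carbon. Going by the values given here, of the measured steps, only that from compound 1 to compound 2 touches this part of the molecule, and there a nitrile-bearing chain in place of an ethoxycarbonyl chain gave a lower number. Compound 4 carries two such chains and loses the methyl as well, so the bearing is loose. A modest further lowering is expected, giving an estimated step of a 2.1-fold lower number from compound 3 to compound 4 (0.32 log units; beyond the scatter) and an estimate for compound 4 of 100 nM, with a plausible range from 25 nM to 500 nM.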

Compound 4, half-maximal effective concentration: 97 nM
Compound 4: middle estimate off by 1.0-fold (0.01 log units), on the high side, within the range that was stated.
By their numbers in this assay, from the lowest: compound 4; then compound 3; then compound 2. At a limit, above all of these: compound 1.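

With the 1-hydroxy-2,2-dimethylpropyl group present in both compounds, the group on the carbonyl carbon still moves the read-out in this assay: the change gives a 2.2-fold lower number from compound 3 to compound 4 (0.34 log units; beyond the scatter). Unlike the earlier step on this side of the molecule, this one joins two actual numbers, so its size can be read directly and it is modest rather than large. Compound 1, the starting point of that earlier step, stands at a limit of the assay, so the earlier step gave only a bound: the limit of > 50000 nM in this assay, at which 1 of the 4 values shown sits.

The step replaces the whole ((ethoxycarbonyl)methyl)(methyl)amino group with the nitrile-bearing group, so the shown compounds cannot say how much of the change belongs to the departing ester chain, the departing methyl or the entering nitrile chains. On these data alone, it also remains open how the number would respond to a carboxylic acid in place of the ethyl ester, to an amine at the end of the chain, or to a longer chain carrying the nitrile.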